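The source may hold more compounds than are shown below. What is called first, only, known or untested is meant among the compounds shown, and "the series" means these compounds.

Working notes on the series. Three measured analogues share the core of compound 1 `COc1ccc(S(=O)(=O)N(Cc2sc3scc(C)c3c2C)[C@H](C)C(=O)NO)cc1`, which in an assay on isolated protein for inhibition of bone morphogenetic protein 1 (Homo sapiens) (on this read-out higher numbers stand for weaker inhibition and lower numbers for stronger inhibition), gives 60 nM. Compound 2 `COc1ccc(S(=O)(=O)N(Cc2cccc(Br)c2)[C@H](C)C(=O)NO)cc1` gives 93 nM in this assay, the highest number of the three; its nearest companion is compound 1, and the two lie within the scatter, while the furthest is compound 3 `COc1ccc(S(=O)(=O)N(Cc2ccccc2C(F)(F)F)[C@H](C)C(=O)NO)cc1`, which in this assay gives 6 nM, a gap that lies beyond the scatter. For the measured compounds named here, no pair of measured compounds differs in a single place, so the change leading to compound 4 `COc1ccc(S(=O)(=O)N(Cc2ccc(F)c(F)c2)[C@H](C)C(=O)NO)cc1` has no measured counterpart in the set. The change is 3,4-difluorophenyl in place of 3-bromophenyl on a saturated chain carbon bound to a sulfonamide nitrogen. The three measured variants at this position differ from one another in more than one feature, so the effect of a halogen change on its own cannot be read from them. For compound 4 the expectation is no step beyond the scatter, with at most a slight lean toward a lower number, the estimated step being a 1.6-fold lower number from compound 2 to compound 4 (0.19 log units; within the scatter). Compound 4 is accordingly expected to give 60 nM in this assay, with a range from 20 nM to 200 nM.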

Compound 4, half-maximal inhibitory concentration: 76 nM
Compound 4: middle estimate off by 1.3-fold (0.10 log units), on the low side, within the range that was stated.
By their numbers in this assay, from the lowest: compound 3; then compounds 1, 4 and 2 (each within the scatter of the next).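

In this assay, for the compounds shown here, 3,4-difluorophenyl in place of 3-bromophenyl on a saturated chain carbon bound to a sulfonamide nitrogen gives a 1.2-fold lower number from compound 2 to compound 4 (0.09 log units; within the scatter) and provides the first comparison that differs in one place. At this position, therefore, the exchange of 3-bromobenzyl for 3,4-difluorobenzyl, one bromine leaving and two fluorines entering, produces no change that can be separated from the scatter. No available data bear on why the two compounds read alike.

On these data alone, whether any halogen is needed here remains open, and a plain benzyl group or an aminobenzyl group would test that. Also open, as far as these compounds go, is what sets compound 3 at 6 nM apart, since it differs from compound 2 and compound 4 in more than one feature and its trifluoromethyl group cannot be assessed alone.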